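Notes on the step from compound 2 to compound 3

This account rests on a few compounds, and the source may have more. Where it says the series, first, only, none or still open, it means among the compounds named here.

Measured so far in a functional assay on MCF7 cells (Homo sapiens), read by MTT assay, with a stated time of 48 h; a higher number here means a weaker inhibitor, a lower number a stronger inhibitor
compound 1 `CCOC(=O)CN(C)C(=O)c1ccc(C(CC)(CC)c2ccc(OCC(O)C(C)(C)C)c(C)c2)n1CC` gives 9200 nM
compound 2 `CCn1c(C(=O)NCCN)ccc1C(CC)(CC)c1ccc(OCC(O)C(C)(C)C)c(C)c1` gives 5.9 nM

Compound 2 holds the lower of the two numbers in this assay and is the reference point here. Compound 3 `CCn1c(C(=O)OCc2ccc(F)cc2)ccc1C(CC)(CC)c1ccc(OCC(O)C(C)(C)C)c(C)c1` carries one change from it (4-fluorobenzyl)oxy in place of (2-aminoethyl)amino on a carbonyl carbon with (4-fluorobenzyl)oxy in place of (2-aminoethyl)amino on a carbonyl carbon. For the measured compounds named here, only one measured step bears on this, and it is large: a 1600-fold lower number from compound 1 to compound 2 (3.19 log units; beyond the scatter) in the series so far. Compound 1 (9200 nM) also lacks the (2-aminoethyl)amino group, so a clearly higher number is expected once that group leaves. Going by the values given here, the entering group differs from the one in compound 1, and no measured compound carries it, so the expected rise need not match that step in size. The expected change is a 120-fold higher number from compound 2 to compound 3 (2.07 log units; beyond the scatter) with a wide margin. The estimate for compound 3 is 700 nM (expected range 40 nM to 10000 nM).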

Compound 3, half-maximal inhibitory concentration: > 50000 nM
Compound 3: only a limit was reported (the forecaster's own chance of this, stated with the estimate: 10%); middle value at least 71-fold (1.85 log units) from the limit.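

In this assay compound 3 gives > 50000 nM, which is a limit of the assay and not a number. Read against that limit, (4-fluorobenzyl)oxy on the carbonyl carbon gives an at least 8400-fold higher number from compound 2 to compound 3 (3.92 log units; beyond the scatter), the second case in which losing (2-aminoethyl)amino comes with a far higher number. The two replacements are also not equivalent, with an at least 5.4-fold higher number from compound 1 to compound 3 (0.73 log units; beyond the scatter), so this position separates even groups that both lack (2-aminoethyl)amino.

Going by these compounds, the true size of both steps stays open, as only a limit is available for compound 3. Also open, on these data alone, is whether the low number of compound 2 depends on the terminal amine, the amide hydrogen or the chain length, which a (2-hydroxyethyl)amino group or a 3-aminopropylamino chain on the same carbonyl carbon would help to separate.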